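The source may hold more compounds than are shown below. What is called first, only, known or untested is meant among the compounds shown, and "the series" means these compounds.

Compound 1 `O=S(=O)(Nc1ccc2oc(-c3ccccc3)nc2c1)c1ccccc1O` — 85000 nM
Compound 2 `O=S(=O)(Nc1ccc(-c2nc3cc(NS(=O)(=O)c4ccccc4O)ccc3o2)cc1)c1ccccc1O` — 18000 nM
Compound 3 `O=S(=O)(Nc1ccc(-c2nc3cc(NS(=O)(=O)c4ccccc4F)ccc3o2)cc1)c1ccccc1F` — 57000 nM

In an assay on cells for inhibition of HSP60/HSP10 (Homo sapiens), with a stated time of 60 min (on this read-out lower numbers stand for stronger inhibition and higher numbers for weaker inhibition), compound 1 gives 85000 nM, the highest of the three numbers shown. Going by the values given here, compound 2 gives 18000 nM, and the step of a 4.7-fold lower number from compound 1 to compound 2 (0.67 log units; beyond the scatter) is the only step between measured compounds that differ in one place. Compound 3 gives 57000 nM, a number that sits within the scatter of the number for compound 1, so no order between those two can be read off.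

The unmeasured compound 4 `O=S(=O)(Nc1ccc2oc(-c3ccccc3)nc2c1)c1cccc(O)c1` differs from compound 1 in one place: 3-hydroxyphenyl in place of 2-hydroxyphenyl on a sulfonyl sulfur. Among the compounds with values here, none of the measured steps bears on this change: the step from compound 1 to compound 2 adds a whole group elsewhere on the shared core, and the pair of compound 1 and compound 3 concerns a different substituent on the same ring. Within the data shown here, the data therefore give no step on which to rest an expectation of a shift in either direction for a move of the hydroxyl on the sulfonyl-bound ring.

The expected step is thus no change at the digits printed from compound 1 to compound 4 (within the scatter), none beyond the scatter. Compound 4 is estimated at 85000 nM in this assay, with a range from 30000 nM to 200000 nM.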

Compound 4, half-maximal inhibitory concentration: 76000 nM
The estimate for compound 4 lay 1.1-fold (0.05 log units) above the measured number, and the stated range covers the measured number.
By their numbers in this assay, from the lowest: compound 2; then compounds 3, 4 and 1 (each within the scatter of the next).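

Going by these compounds alone, the step of a 1.1-fold lower number from compound 1 to compound 4 (0.05 log units; within the scatter) in this assay is the first reading at this position. The earlier steps shown here did not touch the ring on the sulfonyl sulfur whose other neighbour is the sulfonamide nitrogen. With the shared core of compound 1 held constant, 2-hydroxyphenyl and 3-hydroxyphenyl are not separated by this read-out, although the two groups have the same atoms joined differently, so this move of the hydroxyl has no effect that can be read beyond the scatter. That contrasts with the larger step of a 4.7-fold lower number from compound 1 to compound 2 (0.67 log units; beyond the scatter), which adds a ((2-hydroxyphenyl)sulfonyl)amino group elsewhere on the core, and no measurement available here accounts for either result.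

The compounds shown leave open whether the same swap would also stay within the scatter on the larger frame of compound 2, which carries two such sulfonyl groups. They also leave open whether replacing the hydroxyl on this ring with an amine or a carboxylic acid would move the number beyond the scatter in either direction.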